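A few compounds are considered here, and "the series" means these few. Any claim that something is new, unique, unknown or untested is made for them only; others in the source may bear on it.

Of the compounds shown here, two share one core and have been measured in a functional assay, tested at 100 ug/mL; a lower number here means a stronger effect, a higher number a weaker effect of the compound at the concentration tested. Compound 1, `CCOC(=O)C1=C(C)N(c2ccc(Cl)cc2)C=CC1c1ccccc1`, carries an ethyl ester and a 4-chlorophenyl group on the ring nitrogen; in this assay compound 1 gives -20.8%. Compound 2, `CC1=C(C(=O)OC(C)(C)C)C(c2ccccc2)C=CN1c1ccccc1`, carries a tert-butyl ester and a plain phenyl group on the ring nitrogen; in this assay compound 2 gives -23.1%. These two numbers lie within the usual scatter of each other, so neither compound can be called stronger or weaker than the other on what has been measured.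

Compound 3, `CC1=C(C(=O)OC(C)(C)C)C(c2ccccc2)C=CN1c1ccc(Cl)cc1`, keeps the tert-butyl ester of compound 2 and takes the 4-chlorophenyl group seen in compound 1. Set against compound 2, the difference is chloro in place of hydrogen on an aromatic carbon. Among the measured compounds shown here, compound 1 already carries this chloro group and gives a number close to that of compound 2, which is the only guide available. The step from compound 2 to compound 3 is therefore expected to be a number 1.1 percentage points higher from compound 2 to compound 3 (within the scatter), meaning no change beyond the scatter. Compound 3 is expected to give -22%, with a range from -37% to -7%.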

Compound 3, a percentage reported as activity, at one concentration (the size of the read-out at that concentration, not a potency): -19.2%
The estimate for compound 3 lay 2.8 percentage points below the measured number; low and high end bracket the measured number.
By their numbers in this assay, from the lowest: compounds 2, 1 and 3 (each within the scatter of the next).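

In this assay, the change from phenyl to 4-chlorophenyl can now be read alone, with the tert-butyl ester held constant: chloro in place of hydrogen on the aromatic carbon, para to a large group, gives a number 3.9 percentage points higher from compound 2 to compound 3 (within the scatter) and so leaves the read-out unchanged within the usual variation. Among the compounds shown here, the ester can also be read alone for the first time, since the 4-chlorophenyl group stays the same while tert-butyl replaces ethyl on the oxygen next to the carbonyl group, giving a number 1.6 percentage points higher from compound 1 to compound 3 (within the scatter) and again no change that can be told from the scatter. Compounds 1 and 2 differed in both places at once and could not separate these two changes, whereas these single steps show that neither one, on this core, moves the number beyond the scatter, and no measurement here offers an explanation for that. As far as these compounds go, each step has been read only once, so it remains open whether a different group on that aromatic carbon, such as a methoxy group or an amine, would shift the result. The same question stands for the ester, where a carboxylic acid or an amide could behave differently from the ethyl and tert-butyl esters.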